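This account rests on a few compounds, and the source may have more. Where it says the series, first, only, none or still open, it means among the compounds named here.

Working notes on the urea series. For the measured compounds named here, the three compounds measured so far share one core. Compound 1 `Nc1n[nH]c2cccc(-c3cccc(NC(=O)Nc4ccc(Cl)cc4Cl)c3)c12` carries a dichlorophenyl urea, compound 2 `Nc1n[nH]c2cccc(-c3cccc(NC(=O)Nc4ccc(Cl)c(C(F)(F)F)c4)c3)c12` a phenyl urea bearing a chlorine and a trifluoromethyl group, and compound 3 `Nc1n[nH]c2cccc(-c3cccc(NC(=O)Nc4cc(C(F)(F)F)cc(C(F)(F)F)c4)c3)c12` a phenyl urea bearing two trifluoromethyl groups.

In a functional assay on A549 cells (Homo sapiens) for inhibition, read by MTT assay, with a stated time of 48 h (on this read-out lower numbers stand for stronger inhibition and higher numbers for weaker inhibition), compound 1 gives only a limit, > 500000 nM, and no number (the limit of > 500000 nM in this assay, at which 1 of the 3 values shown sits). Compound 2 gives 3410 nM in this assay. Compound 3 gives 1510 nM in this assay, the lowest of the two numbers shown; the gap to compound 2 lies beyond the scatter of the measurement.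

Compound 4 `Nc1n[nH]c2cccc(-c3cccc(NC(=O)Nc4cccc(C(F)(F)F)c4)c3)c12` is not yet measured. It differs from compound 3 by hydrogen in place of trifluoromethyl on an aromatic carbon, the remaining trifluoromethyl group being kept on the six-membered aromatic ring of carbon only. Going by the values given here, no pair of measured compounds isolates this single change, so the expectation rests on the two numbers at hand. Compound 2, with one trifluoromethyl group and a chlorine, gives 3410 nM, a higher number than compound 3.

Compound 4 is therefore expected to give about 4500 nM in this assay, within 1500 nM to 14000 nM. The step from compound 3 to compound 4 is expected at a 3.0-fold higher number from compound 3 to compound 4 (0.47 log units; beyond the scatter), a weakening beyond the scatter.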

Compound 4, half-maximal inhibitory concentration: 1950 nM
Estimate against measurement, compound 4: 2.3-fold (0.36 log units) above; the range from low to high includes it.
By their numbers in this assay, from the lowest: compounds 3, 4 and 2 (each within the scatter of the next, the first and the last beyond it). At a limit, above all of these: compound 1.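

Hydrogen in place of trifluoromethyl at this position, on an aromatic carbon meta to a trifluoromethyl group, can now be read directly in this assay: it gives a 1.3-fold higher number from compound 3 to compound 4 (0.11 log units; within the scatter), so the second trifluoromethyl group is not needed to hold the number at this level. Hydrogen in place of chloro on an aromatic carbon likewise gives a 1.7-fold lower number from compound 2 to compound 4 (0.24 log units; within the scatter), so among these compounds a single trifluoromethyl group on this ring serves as well as either pair of groups with a trifluoromethyl group in it. Much larger is the step for 3-(trifluoromethyl)phenyl in place of 2,4-dichlorophenyl on an amide-type nitrogen, an at least 250-fold lower number from compound 1 to compound 4 (2.40 log units; beyond the scatter), one end of which is a limit and not a number: the limit of > 500000 nM in this assay, at which 1 of the 4 values shown sits.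

From the compounds shown here alone, what a methoxy group, an amine or a carboxylic acid would give on this aromatic carbon stays open, as does the result for a plain phenyl urea with hydrogen in place of the remaining trifluoromethyl group. Which of the two chlorines of the 2,4-dichlorophenyl group goes with the limit also stays open, as that step changes more than one place on the ring.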